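Moving a ring nitrogen: compound 3 to compound 4

A few compounds are considered here, and "the series" means these few. Any claim that something is new, unique, unknown or untested is made for them only; others in the source may bear on it.

The measured compounds, each with its value in a physicochemical assay for lipophilicity, read by HPLC, at pH 3.0; a higher number here means a more lipophilic compound, a lower number a more polar compound:
Compound 1, `NCc1csc(NC(=O)c2ccn[nH]2)n1`, gives 0.
Compound 2, `NCc1csc(NC(=O)c2cnnn2Cc2ccccc2)n1`, gives 1.3.
Compound 3, `CC(C)(C)c1cc(C(=O)Nc2ccncc2)n(Cc2ccccc2)n1`, gives 2.6.

Among these three, compound 3 stands highest in this assay. Its distance to compound 2 is beyond the scatter, and its distance to compound 1 is larger still, so compound 3 is clearly the most lipophilic of the set. No two of the measured compounds differ in only one place, so none of them gives a direct reading of how a single small change moves this number.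

Compound 4, `CC(C)(C)c1cc(C(=O)Nc2cccnc2)n(Cc2ccccc2)n1`, has not yet been measured. It is built from the same atoms as compound 3, joined differently: pyridin-3-yl in place of pyridin-4-yl on an amide-type nitrogen. Both groups are one six-membered aromatic ring with one hetero atom, carrying one hydrogen-bond acceptor and no net charge, so what is counted does not change at all.

For the measured compounds named here, with no measured pair of this kind to lean on, the expectation is a small step only. Compound 4 is estimated at 2.8, with a likely range from 2.3 to 3.3, which means an expected step of a number 0.20 log units higher from compound 3 to compound 4 (within the scatter) that stays within the usual scatter.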

Compound 4, distribution coefficient: 3.5
Compound 4: middle estimate off by 0.70 log units, on the low side, outside the stated range (above it).
By their numbers in this assay, from the lowest: compound 1; then compound 2; then compound 3; then compound 4.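

For the compounds shown here, this is the first pair in the set that differs in only one place, so it gives the first direct reading of a single change in this assay: pyridin-3-yl in place of pyridin-4-yl on the amide-type nitrogen gives a number 0.90 log units higher from compound 3 to compound 4 (beyond the scatter). The step shows that at this place, moving the ring nitrogen alone can shift the number by more than repeat measurements would, even though the heavy atoms, hydrogen-bond donors and acceptors, and net charge counted for the two groups are the same. No measurement shown here accounts for the size of this step.

The compounds shown leave open where the number would fall with pyridin-2-yl, the remaining placing of this ring nitrogen, or with a plain phenyl ring, which has no ring nitrogen, on the same amide-type nitrogen. Going by these compounds alone, with only this one pair, it also remains open whether a step of this size belongs to the swap in general or only to the core shared by compound 3 and compound 4.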